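A few compounds are considered here, and "the series" means these few. Any claim that something is new, unique, unknown or untested is made for them only; others in the source may bear on it.

Measured in an ADME assay on KB cells (Homo sapiens) for cytotoxicity, read by resazurin assay, with a stated time of 72 h; a lower number here means a stronger inhibitor, a higher number a weaker inhibitor:
compound 1 `Cc1c(OCc2ccccc2)c(=O)ccn1CCCCNc1ccnc2cc(Cl)ccc12` gives 119000 nM
compound 2 `Cc1c(O)c(=O)ccn1CCCCNc1ccnc2cc(Cl)ccc12` gives 185000 nM
compound 3 `CCc1c(OCc2ccccc2)c(=O)ccn1CCCNc1ccnc2cc(Cl)ccc12` gives 15000 nM

Compound 1 and compound 2 share a core and differ in one place: hydrogen in place of benzyl on an oxygen on an aromatic ring. That step, a 1.6-fold higher number from compound 1 to compound 2 (0.19 log units; within the scatter), is small. Compound 3 is built on a different core; how the two cores differ is not broken down here. Compound 4 `CCc1c(O)c(=O)ccn1CCCNc1ccnc2cc(Cl)ccc12` is the counterpart of compound 3 with the same change applied: hydrogen in place of benzyl on an oxygen on an aromatic ring. Because the earlier step of a 1.6-fold higher number from compound 1 to compound 2 (0.19 log units; within the scatter) stayed within the scatter, a similarly small step is expected here too, a 1.5-fold higher number from compound 3 to compound 4 (0.17 log units; within the scatter), and this rests on one pair only. Compound 4 is therefore estimated at 22000 nM in this assay, most likely between 9000 nM and 55000 nM.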

Compound 4, half-maximal inhibitory concentration: 55000 nM
For compound 4 the middle estimate is 2.5-fold (0.40 log units) below the measured one; low and high end bracket the measured number.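

On the second core, hydrogen in place of benzyl on the oxygen gives a 3.7-fold higher number from compound 3 to compound 4 (0.56 log units; beyond the scatter) in this assay, a modest step. Set beside the step on the first core, this one does not stand apart by more than the scatter of two such steps allows: the same change on two cores in this assay, a 1.6-fold higher number (0.19 log units; within the scatter) from compound 1 to compound 2 and a 3.7-fold higher number (0.56 log units; beyond the scatter) from compound 3 to compound 4, 2.4-fold (0.37 log units) apart, within the scatter of two such steps. The result fits the change carrying across these two cores, but two pairs cannot show that its size is truly the same or predict its size on a further core.

From the compounds shown here alone, only benzyl and hydrogen appear on that oxygen, so the effect of a small group such as methyl or of a longer chain there remains open. Going by these compounds, whether an amine in place of the hydroxy would behave differently also remains open.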